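The source may hold more compounds than are shown below. What is called first, only, known or untested is meant among the compounds shown, and "the series" means these compounds.

Compound 1 `O=S(=O)(NCCCNCc1ccc(Cl)cc1)c1cc(C(F)(F)F)cc(C(F)(F)F)c1`: 1800 nM
Compound 2 `O=S(=O)(NCCCNCc1cccc(Cl)c1)c1cc(C(F)(F)F)cc(C(F)(F)F)c1`: 2200 nM
Compound 3 `O=S(=O)(NCCCNCc1ccccc1Cl)c1cc(C(F)(F)F)cc(C(F)(F)F)c1`: 9300 nM

In a functional assay on A2780 cells (Homo sapiens) for inhibition, read by MTT assay, with a stated time of 72 h (a higher number here means a weaker inhibitor of growth, a lower number a stronger inhibitor of growth), compound 1 gives the lowest of these three numbers. Its nearest neighbour is compound 2, and a 1.2-fold higher number from compound 1 to compound 2 (0.09 log units; within the scatter) lies within the scatter; its furthest is compound 3, and a 5.2-fold higher number from compound 1 to compound 3 (0.71 log units; beyond the scatter) lies beyond it. Compound 4 `O=S(=O)(NCCCNCc1ccc(-c2ccccc2)cc1)c1cc(C(F)(F)F)cc(C(F)(F)F)c1` differs from compound 1 by phenyl in place of chloro on an aromatic carbon. For the measured compounds named here, none of the measured steps bears directly on this change: a 1.2-fold higher number from compound 1 to compound 2 (0.09 log units; within the scatter), a 5.2-fold higher number from compound 1 to compound 3 (0.71 log units; beyond the scatter) and a 4.2-fold higher number from compound 2 to compound 3 (0.63 log units; beyond the scatter) each exchange one chlorophenyl for another, and none replaces the chloro group with anything. No step beyond the scatter in this assay is therefore expected in either direction. Compound 4 is expected to give 1500 nM, with a range of 500 nM to 5000 nM. The step this estimate means, a 1.2-fold lower number from compound 1 to compound 4 (0.08 log units; within the scatter), is expected to stay within the scatter.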

Compound 4, concentration for 50% growth inhibition: 2600 nM
The estimate for compound 4 lay 1.7-fold (0.24 log units) below the measured number; the measured number falls inside the stated range.
By their numbers in this assay, from the lowest: compounds 1, 2 and 4 (each within the scatter of the next); then compound 3.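

In this assay, phenyl in place of chloro on this aromatic carbon gives a 1.4-fold higher number from compound 1 to compound 4 (0.16 log units; within the scatter). The earlier compounds shown here only moved the chlorine around its ring, whereas this step shows that at the position para to a large group, a six-membered aromatic ring of carbon only can replace the chlorine without a change beyond the scatter. Nothing available explains this outcome.

Going by these compounds, whether an amine or a carboxylic acid on this same carbon would fit the same picture remains open. So does whether phenyl in place of the chloro of compound 3 would give a similar result.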